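Swapping Trifluoromethyl for Chloro on the Triazole Aryl

The compounds below may be only part of what the source reports. "The series", "measured", "known", "first", "only" and "open" are said of these compounds alone.

Three compounds built on a shared core differ only in the aromatic group attached to the triazole. Compound 1 (`C=C1C[C@]23C[C@@]1(O)CC[C@H]2c1cc(Br)c(O)c(C)c1[C@@H]3Cn1cc(-c2ccccc2)nn1`) carries an unsubstituted phenyl. In a functional assay on MCF7 cells (Homo sapiens) for cytotoxicity, read by MTT assay, with a stated time of 4 days (on this read-out lower numbers stand for stronger inhibition and higher numbers for weaker inhibition), compound 1 gives > 20000 nM, which is a limit of the assay and not a number. Compound 2 (`C=C1C[C@]23C[C@@]1(O)CC[C@H]2c1cc(Br)c(O)c(C)c1[C@@H]3Cn1cc(-c2ccccn2)nn1`) carries pyridin-2-yl in place of phenyl. In this assay compound 2 gives > 20000 nM, again a limit. For the measured compounds named here, compound 3 (`C=C1C[C@]23C[C@@]1(O)CC[C@H]2c1cc(Br)c(O)c(C)c1[C@@H]3Cn1cc(-c2ccc(C(F)(F)F)cc2)nn1`) carries trifluoromethyl on the phenyl, and in this assay compound 3 gives 8100 nM, the only number among the three. On these data alone, the step of an at least 2.4-fold lower number from compound 1 to compound 3 (0.39 log units; beyond the scatter) and the step of an at least 2.4-fold lower number from compound 2 to compound 3 (0.39 log units; beyond the scatter) are both cut off by the limit of > 20000 nM in this assay, at which 2 of the 3 values shown sit, so their full size is unknown, and the step that the two limits leave unreadable from compound 1 to compound 2 cannot be read at all.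

Compound 4 (`C=C1C[C@]23C[C@@]1(O)CC[C@H]2c1cc(Br)c(O)c(C)c1[C@@H]3Cn1cc(-c2ccc(Cl)cc2)nn1`) differs from compound 3 by chloro in place of trifluoromethyl on an aromatic carbon. Going by the values given here, only the step of an at least 2.4-fold lower number from compound 1 to compound 3 (0.39 log units; beyond the scatter) bears on a substituent at this place, and it is at least modest. A chloro is expected to land between hydrogen and trifluoromethyl, so in this assay compound 4 is estimated at 13000 nM, with a range from 4500 nM to 40000 nM. This estimate means a 1.6-fold higher number from compound 3 to compound 4 (0.21 log units; within the scatter), a weaker result that may well appear only as a limit.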

Compound 4, half-maximal inhibitory concentration: 10200 nM
Compound 4: the middle estimate sits 1.3-fold (0.11 log units) above what was measured, within the range that was stated.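

In this assay, chloro in place of trifluoromethyl on this aromatic carbon gives a 1.3-fold higher number from compound 3 to compound 4 (0.10 log units; within the scatter), so the two groups cannot be told apart here, and a second substituent at this place now yields a measured number and not a limit. Against the unsubstituted phenyl, chloro gives an at least 1.9-fold lower number from compound 1 to compound 4 (0.29 log units; that floor lies within the scatter), and against pyridin-2-yl, 4-chlorophenyl gives an at least 1.9-fold lower number from compound 2 to compound 4 (0.29 log units; that floor lies within the scatter). Neither floor by itself clears the scatter, and the full size of both steps stays unknown: the limit of > 20000 nM in this assay, at which 2 of the 4 values shown sit.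

The compounds shown leave open whether an amine or a carboxylic acid on this aromatic carbon would give a number that differs from those of compound 3 and compound 4 by more than the scatter. On these data alone, whether a longer chain in place of chloro would keep a measured number, or return to a limit as with compound 1 and compound 2, also stays open.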